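A few compounds are considered here, and "the series" means these few. Any claim that something is new, unique, unknown or untested is made for them only; others in the source may bear on it.

Compound 1 `CCN(CC)C(=O)C1=C(C)NC(=O)NC1c1cccs1`: 31%
Compound 2 `CC1=C(C(=O)NC(C)C)C(c2ccsc2)NC(=O)N1`: 1%

In an assay on membranes from HeLa cells for displacement of a labelled ligand from adenosine receptor A3 (Homo sapiens), read by scintillation counting, with a stated time of 180 min, tested at 1 uM (a higher number here means more inhibition at the concentration tested (going by the name of the read-out), a lower number less inhibition), compound 1 gives 31%, while compound 2 gives 1%, the lower of the two numbers and beyond the scatter from compound 1. Compound 3 `CCN(CC)C(=O)C1=C(C)NC(=O)NC1c1ccsc1` has not yet been measured. It differs from compound 2 in one place: diethylamino in place of isopropylamino on a carbonyl carbon. Compound 1 carries the same diethylamino group and gives 31% in this assay, so a rise is expected for compound 3, though compound 1 also differs from compound 3 elsewhere. The expected step from compound 2 to compound 3 is a number 19 percentage points higher from compound 2 to compound 3 (beyond the scatter), an increase beyond the scatter. Compound 3 is therefore estimated at 20%, within a range from 0% to 45%.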

Compound 3, a percentage reported as inhibition, at one concentration (the size of the read-out at that concentration, not a potency): 35%
Beside the measured number, compound 3's estimate is 15 percentage points below it; the range from low to high includes it.
By their numbers in this assay, from the lowest: compound 2; then compounds 1 and 3 (each within the scatter of the next).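

With thiophen-3-yl held fixed, diethylamino in place of isopropylamino on a carbonyl carbon gives a number 34 percentage points higher from compound 2 to compound 3 (beyond the scatter) in this assay and so marks this position as one where the change matters. With diethylamino held fixed, thiophen-3-yl in place of thiophen-2-yl on a saturated ring carbon gives a number 4 percentage points higher from compound 1 to compound 3 (within the scatter) and so separates the two thiophene attachments by nothing beyond the scatter.

Still open, from the compounds shown here alone, is how a cyclic amine such as piperidine or a longer chain such as dipropylamino would read on that carbonyl carbon, and how a phenyl group would read on the ring carbon. Nothing measured here explains the size of the amide step.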